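Swapping the hydroxy-indanyl arm for a pyridinylmethyl arm

This account rests on a few compounds, and the source may have more. Where it says the series, first, only, none or still open, it means among the compounds named here.

Measured compounds:
compound 1 `O[C@H]1Cc2ccccc2C1NC1CCN(CCCc2c[nH]c3ccc(-n4cnnc4)cc23)CC1` with 300 nM
compound 2 `OC[C@H](NC1CCN(CCCc2c[nH]c3ccc(-n4ccnc4)cc23)CC1)c1ccccc1` with 100 nM
compound 3 `COC[C@H](NC1CCN(CCCc2c[nH]c3ccc(Cn4cncn4)cc23)CC1)c1ccc(F)cc1` with 1200 nM

Of the compounds shown here, three have been tested in an assay on CHO cells for displacement of a labelled ligand from 5-hydroxytryptamine receptor 1B (Homo sapiens) (a higher number here means a weaker inhibitor, a lower number a stronger inhibitor), all sharing a core in which a piperidine is linked through a three-carbon chain to an indole carrying a small aromatic ring. In this assay compound 1 gives 300 nM, the second highest of the three numbers. Compound 2 gives 100 nM, a lower number than compound 1, and the gap between the two lies beyond the usual scatter. Compound 3 gives 1200 nM, a higher number than compound 1, again beyond the scatter.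

The next compound, compound 4 `c1cncc(CNC2CCN(CCCc3c[nH]c4ccc(-n5cnnc5)cc34)CC2)c1`, keeps the core of compound 1 and alters only the group on the amine nitrogen: (pyridin-3-yl)methyl in place of 2-hydroxy-2,3-dihydro-1H-inden-1-yl on an amine nitrogen. The hydroxyl on the indanyl arm of compound 1 is lost, and a pyridine ring with a single methylene now sits on that nitrogen.

Going by the values given here, no measured pair shows this exact change, so its effect can only be guessed from the spread of the three values. A modest weakening is expected, with the step from compound 1 to compound 4 estimated as a 2.0-fold higher number from compound 1 to compound 4 (0.30 log units; within the scatter). Compound 4 is therefore estimated at 600 nM, with a range from 150 nM to 2500 nM.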

Compound 4, half-maximal inhibitory concentration: 140 nM
Estimate against measurement, compound 4: 4.3-fold (0.63 log units) above; measured number outside the range, below it.
By their numbers in this assay, from the lowest: compounds 2 and 4 (each within the scatter of the next); then compound 1; then compound 3.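

In this assay, going by these compounds alone, this is the first step in the set where only one place differs, and it gives a direct reading of the group on the amine nitrogen: a 2.1-fold lower number from compound 1 to compound 4 (0.33 log units; beyond the scatter). The 2-hydroxy-2,3-dihydro-1H-inden-1-yl group, with its hydrogen-bond donor and defined stereocentre, can therefore give way to a (pyridin-3-yl)methyl group, which has fewer heavy atoms, with a modest gain, at least on the core of compound 1. No measurement here accounts for this gain, so the step describes what happened but does not explain it.

The swap changes the hydroxyl, the carbon ring system, the stereocentre and the ring nitrogen all at once, so the step cannot be assigned to any one of them. A benzyl group on the same amine nitrogen would test the pyridine nitrogen, (pyridin-2-yl)methyl and (pyridin-4-yl)methyl groups would test its placement, and a 2,3-dihydro-1H-inden-1-yl group without the hydroxyl would isolate the contribution of that hydroxyl.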